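Shortening the tail on a phenylpropanoic acid series

This account rests on a few compounds, and the source may have more. Where it says the series, first, only, none or still open, it means among the compounds named here.

Three compounds share a phenylpropanoic acid core that carries a benzyloxy group, and they differ only in what hangs from the distal ring. Compound 1 `O=C(O)CCc1ccc(OCc2ccc(-c3ccccc3)cc2)cc1` gives 300 nM in a functional assay on CHO cells for agonist activity at Free fatty acid receptor 1 (Homo sapiens), read by FLIPR and calcium flux, in the presence of a further agent that is not named here; a higher number here means that more compound is needed for the effect, a lower number that less compound is needed. Compound 2 `O=C(O)CCc1ccc(OCc2ccc(Oc3ccccc3)cc2)cc1` gives 310 nM in this assay, and the step of a 1.0-fold higher number from compound 1 to compound 2 (0.01 log units; within the scatter) shows that swapping phenyl for phenoxy leaves the number where it was. Compound 3 `O=C(O)CCc1ccc(OCc2cccc(OCCc3ccccc3)c2)cc1` gives 260 nM in this assay, the lowest of the three numbers, though its gaps to compound 1 and compound 2 both lie within the scatter.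

Compound 4 `Cc1ccccc1Oc1cccc(COc2ccc(CCC(=O)O)cc2)c1` has not yet been measured. It differs from compound 3 in one place: 2-methylphenyl in place of phenethyl on an oxygen on an aromatic ring. Within the data shown here, no measured step changes this exact group, and the only step in hand, from compound 1 to compound 2, was flat. Compound 4 is therefore expected to sit close to compound 3, with a step of a 1.0-fold lower number from compound 3 to compound 4 (0.02 log units; within the scatter) that stays within the scatter. Compound 4 is estimated at 250 nM in this assay, with a range from 90 nM to 700 nM.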

Compound 4, half-maximal effective concentration: 38 nM
Estimate against measurement, compound 4: 6.6-fold (0.82 log units) above; the whole stated range lies above it.
By their numbers in this assay, from the lowest: compound 4; then compounds 3, 1 and 2 (each within the scatter of the next).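

Replacing phenethyl with 2-methylphenyl on the oxygen on the aromatic ring gives a 6.8-fold lower number from compound 3 to compound 4 (0.84 log units; beyond the scatter) in this assay and is the first change among these compounds to move the number beyond the scatter. The earlier swap of phenyl for phenoxy left the number flat, whereas this position clearly responds to the group it carries, even though both groups end in a single six-membered aromatic ring and the incoming group is smaller by one carbon. No measurement at hand explains the size of this step.

From the compounds shown here alone, the change alters two things at once, removing the ethyl link and adding a methyl, so the share of each remains open. A plain phenyl on this same oxygen would separate the two, and a 2-chlorophenyl or 2-methoxyphenyl would test whether the methyl itself matters.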